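Phenyl replaces the hydroxymethyl pyrrolidine: working notes

A few compounds are considered here, and "the series" means these few. Any claim that something is new, unique, unknown or untested is made for them only; others in the source may bear on it.

Measured in a physicochemical assay for solubility, in phosphate buffer, at pH 7.4; on this read-out lower numbers stand for lower solubility and higher numbers for higher solubility:
- compound 1 `OCC1CCN(c2nccnc2OC2CN(c3ncc4ccccc4n3)C2)CC1`: 174000 nM
- compound 2 `OCC1CCN(c2nccnc2OC2CN(c3ccc4ccccc4n3)C2)C1`: 167000 nM

Compound 2 stands level with compound 1 on these numbers, the two lying within the scatter of each other. Compound 3 `c1ccc(-c2nccnc2OC2CN(c3ccc4ccccc4n3)C2)cc1` carries phenyl in place of 3-(hydroxymethyl)pyrrolidin-1-yl on an aromatic carbon. Going by the values given here, no measured step covers such an exchange, so the expectation rests on the structural change alone: a clear drop in this assay, beyond the scatter. The estimated step is a 17-fold lower number from compound 2 to compound 3 (1.22 log units; beyond the scatter). For compound 3 the expected value is 10000 nM, with an estimated range of 1500 nM to 50000 nM.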

Compound 3, solubility: < 1000 nM
Compound 3: only a limit was reported; the forecaster's own chance of this, stated with the estimate: 15%; middle value at least 10-fold (1.00 log units) away from the limit.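

At this position, on an aromatic carbon next to the ring nitrogen, phenyl in place of 3-(hydroxymethyl)pyrrolidin-1-yl gives in this assay an at least 160-fold lower number from compound 2 to compound 3 (2.22 log units; beyond the scatter), the only step shown that lies beyond the scatter. That size is a bound and not a measured gap, as the entry for compound 3 is a limit of the assay: the limit of < 1000 nM in this assay, at which 1 of the 3 values shown sits.

Going by these compounds, it remains open whether the hydroxymethyl or the saturated ring matters more here. An unsubstituted pyrrolidine, or a phenyl carrying hydroxymethyl or an amine, would separate the two.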